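This account rests on a few compounds, and the source may have more. Where it says the series, first, only, none or still open, it means among the compounds named here.

Compound 1 `CCN(CC)C/C1=C/C[C@](C)(CCC=C(C)C)/C=C/[C@@H](OC(=O)C=C(C)C)[C@](C)(O)/C=C/C1=O` is a non-aromatic ring of carbon only carrying several side groups. In a functional assay on A549 cells (Homo sapiens) for antiproliferative activity, read by MTT assay, with a stated time of 48 h (on this read-out lower numbers stand for stronger inhibition and higher numbers for weaker inhibition), compound 1 gives 130 nM, the lower of the two numbers measured here. Among the compounds with values here, the only other measured compound, compound 2 `CC(C)=CCC[C@](C)(/C=C/[C@@H](OC(=O)C=C(C)C)[C@](C)(O)/C=C/C(=O)/C=C/N1CCN(C)CC1)CC=O`, has an open chain in place of the ring and gives 2660 nM in this assay, a gap from compound 1 that lies beyond the scatter. Compound 3 `CCN(CC)C(=O)/C1=C/C[C@](C)(CCC=C(C)C)/C=C/[C@@H](OC(=O)C=C(C)C)[C@](C)(O)/C=C/C1=O` keeps the ring of compound 1 and changes one group on it: diethylcarbamoyl in place of (diethylamino)methyl on a double-bonded ring carbon. Within the data shown here, no measured pair shows this exact exchange, so the direction of its effect is not fixed by the data. A modest weakening in this assay is expected, with the step from compound 1 to compound 3 estimated at a 3.1-fold higher number from compound 1 to compound 3 (0.49 log units; beyond the scatter). Compound 3 is therefore expected to give about 400 nM in this assay, within a range from 100 nM to 1600 nM.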

Compound 3, half-maximal inhibitory concentration: 11300 nM
The estimate for compound 3 lay 28-fold (1.45 log units) below the measured number; the measured number lies above the stated range.
By their numbers in this assay, from the lowest: compound 1; then compound 2; then compound 3.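

In this assay the exchange of (diethylamino)methyl for diethylcarbamoyl on this double-bonded ring carbon gives an 87-fold higher number from compound 1 to compound 3 (1.94 log units; beyond the scatter) and so shows that this position is far from indifferent to change. The two groups share a nitrogen bearing two ethyl groups, so that feature alone does not keep the activity of compound 1 when the group that carries it changes. Nothing measured here explains why the loss is so large.

From the compounds shown here alone, it remains open whether other amines at this ring carbon, such as piperidin-1-ylmethyl or morpholin-4-ylmethyl, would match (diethylamino)methyl. Going by these compounds, it is equally open whether a carboxylic acid or a methyl ester in the same place would fall as far as diethylcarbamoyl does.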